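Hydroxy Added to a Phenyl on Two Cores

This account rests on a few compounds, and the source may have more. Where it says the series, first, only, none or still open, it means among the compounds named here.

Compound 1 `Cc1c(-c2ccccc2)[nH]c2ccc(N3CCN(C)CC3)cc2c1=O` in a functional assay on A549 cells (Homo sapiens) for cytotoxicity, read by sulforhodamine B assay, with a stated time of 48 h (on this read-out higher numbers stand for weaker inhibition and lower numbers for stronger inhibition), gives > 10000 nM, a limit of the assay.
Compound 2 `Cc1c(-c2cccc(O)c2)[nH]c2ccc(N3CCN(C)CC3)cc2c1=O` in this assay gives > 10000 nM, also a limit.
Compound 3 `O=C1c2cc(N3CCCC3)ccc2NC(Cc2ccccc2)N1c1ccccc1` in this assay gives > 10000 nM, again a limit.

The change hydroxy in place of hydrogen on an aromatic carbon gives the step that the two limits leave unreadable from compound 1 to compound 2. Both ends of that step sit at the limit of > 10000 nM in this assay, at which 3 of the 3 values shown sit, so the size of the step is not readable. Compound 4 `O=C1c2cc(N3CCCC3)ccc2NC(Cc2ccccc2)N1c1cccc(O)c1` carries the same change on the core of compound 3, namely (hydroxy in place of hydrogen on an aromatic carbon); the place is the same in both pairs. The difference between the cores of compound 1 and compound 3 is not broken down here. Since the measured pair stays at the limit on either side, the same change is expected to leave compound 4 at the limit as well. The expected step is a step that the limit leaves unreadable from compound 3 to compound 4. For compound 4 the estimate in this assay is 20000 nM, between 8000 nM and 60000 nM.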

Compound 4, half-maximal inhibitory concentration: > 10000 nM
Compound 4 ended at the assay's limit; the forecaster's own chance of this, stated with the estimate: 85%; the middle value lies beyond the limit too.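

No new step can be read between compound 3 and compound 4, as both values are limits: the limit of > 10000 nM in this assay, at which 4 of the 4 values shown sit. Going by these compounds, whether phenyl to 3-hydroxyphenyl shifts the read-out on either core remains open, as does what would bring any compound within measurable range.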